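Adding a tert-Butyl Group to a Weak Triazole Inhibitor

This account rests on a few compounds, and the source may have more. Where it says the series, first, only, none or still open, it means among the compounds named here.

Within the data shown here, compound 2 `COC1=C(OC)C(O)(CCn2cc(-c3ccccc3)nn2)NC1=O` is the only compound here with a numerical result: in a functional assay on MDA-MB-231 cells (Homo sapiens) for antiproliferative activity, read by MTT assay, with a stated time of 24 h (a lower number here means a stronger inhibitor, a higher number a weaker inhibitor), compound 2 gives 18300 nM, a weak inhibition. Compound 1 `CC(C)(C)c1ccc(-c2cn(CCC3(O)NC(=O)C(OCc4ccccc4)=C3OCc3ccccc3)nn2)cc1` reaches only a limit of the assay; in this assay compound 1 is recorded as > 100000 nM, which is the limit of > 100000 nM in this assay, at which 1 of the 2 values shown sits. Compound 1 and compound 2 differ from each other in several places at once, so their two values show no more than that one sits at the limit while the other gives a weak number.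

Compound 3 `COC1=C(OC)C(O)(CCn2cc(-c3ccc(C(C)(C)C)cc3)nn2)NC1=O` has not yet been measured. It differs from compound 2 by tert-butyl in place of hydrogen on an aromatic carbon. Among the measured compounds shown here, no pair of measured compounds isolates this single change, so no measured step guides the expectation. With compound 2 already weak at 18300 nM, the expected step of a 1.4-fold higher number from compound 2 to compound 3 (0.14 log units; within the scatter) is small, within or barely beyond the scatter, with if anything a drift toward weaker inhibition. Compound 3 is therefore expected to give about 25000 nM in this assay, estimated to lie between 8000 nM and 80000 nM.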

Compound 3, half-maximal inhibitory concentration: 11300 nM
Beside the measured number, compound 3's estimate is 2.2-fold (0.34 log units) above it; measured number inside the range.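

In this assay, tert-butyl in place of hydrogen on an aromatic carbon, para to a large group, is the one single change that can be read among the compounds shown, and it gives a 1.6-fold lower number from compound 2 to compound 3 (0.21 log units; within the scatter). This position therefore accepts a tert-butyl group without a change that can be told from the usual scatter, and the antiproliferative result remains weak, neither gained nor lost through this substitution. Compound 1, which also carries the tert-butyl group but differs elsewhere, stands as the only compound recorded at a limit of the assay: the limit of > 100000 nM in this assay, at which 1 of the 3 values shown sits.

Nothing measured here gives a reason for the size of this step, and no evidence shown bears on it.

As far as these compounds go, it remains open whether another group at this place, such as an amine, a carboxylic acid or a longer chain, would move the number beyond the scatter, and whether a change elsewhere on the shared core, taken alone, would do so.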